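The source may hold more compounds than are shown below. What is called first, only, known or untested is meant among the compounds shown, and "the series" means these compounds.

Compound 1 `COc1ccc(-n2nc(C(N)=O)nc2-c2cc(OC)c(OC)c(OC)c2)cc1`: 71%
Compound 2 `CNC(=O)c1nc(-c2cc(OC)c(OC)c(OC)c2)n(-c2ccc(OC)cc2)n1`: 65%
Compound 3 `COc1ccc(NC(=O)c2nc(-c3cc(OC)c(OC)c(OC)c3)n(-c3ccc(OC)cc3)n2)cc1`: 63%

In a functional assay on the whole organism for inhibition, with Rattus norvegicus as the target, read by paw edema, with stated times of 30 min and 4 h, at a dose of 0.28 mmol/kg by the oral route (on this read-out lower numbers stand for less inhibition and higher numbers for more inhibition at the one dose given (going by the name of the read-out)), compound 1 gives 71%, the highest of the three numbers, although its nearest neighbour compound 2 and its furthest neighbour compound 3 both lie within the usual scatter of it. Compound 4 `COc1ccc(-n2nc(C(=O)Nc3ccccc3C)nc2-c2cc(OC)c(OC)c(OC)c2)cc1` differs from compound 1 in one place: 2-methylphenyl in place of hydrogen on an amide-type nitrogen. Within the data shown here, two measured steps bear on this change, since both also replace the hydrogen on the same amide-type nitrogen. Methyl in place of that hydrogen gave a number 6 percentage points lower from compound 1 to compound 2 (within the scatter), and 4-methoxyphenyl in place of it gave a number 8 percentage points lower from compound 1 to compound 3 (within the scatter). Neither step reached beyond the scatter, and the second of them, an aromatic ring on the same nitrogen, is the closest parallel to the change now at hand. Compound 4 is therefore expected to show no step beyond the scatter in this assay, with the estimated step being a number 7 percentage points lower from compound 1 to compound 4 (within the scatter). The estimate for compound 4 is 64%, with a range from 50% to 78%.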

Compound 4, a percentage reported as inhibition, in the whole organism at one dose (the size of the read-out at that dose, not a potency): 46%
Compound 4: middle estimate off by 18 percentage points, on the high side; measured number outside the range, below it.
By their numbers in this assay, from the lowest: compound 4; then compounds 3, 2 and 1 (each within the scatter of the next).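

In this assay, among these compounds, the group on the amide-type nitrogen turns out to matter: 2-methylphenyl in place of hydrogen gives a number 25 percentage points lower from compound 1 to compound 4 (beyond the scatter), the only step from compound 1 at this position that lies beyond the scatter. An aromatic ring on this nitrogen does not by itself set the number, since 2-methylphenyl in place of 4-methoxyphenyl gives a number 17 percentage points lower from compound 3 to compound 4 (beyond the scatter), while 2-methylphenyl in place of methyl gives a number 19 percentage points lower from compound 2 to compound 4 (beyond the scatter). Nothing measured here says why the 2-methylphenyl group goes with the lower number.

The 2-methylphenyl and 4-methoxyphenyl groups differ both in what the ring carries and in where it carries it, so these compounds cannot show which of the two differences counts. Plain phenyl, 4-methylphenyl and 2-methoxyphenyl on this nitrogen would separate them, and a longer chain such as butyl remains an open case too.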